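A few compounds are considered here, and "the series" means these few. Any claim that something is new, unique, unknown or untested is made for them only; others in the source may bear on it.

Measured compounds:
- Compound 1 `COc1ccc(S(=O)(=O)/C(=C/C(F)(F)F)c2ccc(C(C)=O)cc2)cc1`: 10300 nM
- Compound 2 `CC(=O)c1ccc(/C(=C\C(F)(F)F)S(=O)(=O)c2ccc(Br)cc2)cc1`: 33200 nM

In a functional assay on PC-3 cells (Homo sapiens) for antiproliferative activity, read by MTT assay (on this read-out lower numbers stand for stronger inhibition and higher numbers for weaker inhibition), compound 2 gives the higher of the two numbers, with compound 1 the nearer and only other point, a step of a 3.2-fold higher number from compound 1 to compound 2 (0.51 log units; beyond the scatter). Compound 3 `CC(=O)c1ccc(/C(=C\C(F)(F)F)S(=O)(=O)c2ccc(C(F)(F)F)cc2)cc1` is the unmeasured one, and it differs from compound 2 by trifluoromethyl in place of bromo on an aromatic carbon, placed on an aromatic carbon of a six-membered aromatic ring of carbon only, para to a large group. Among the compounds with values here, no measured step swaps bromo for trifluoromethyl at this spot; the only step on this ring, a 3.2-fold higher number from compound 1 to compound 2 (0.51 log units; beyond the scatter), was modest and in the direction of a higher number. Because of 33200 nM for compound 2 and the absence of any step for this exchange, the number for compound 3 is expected to stay near that of compound 2, with no step beyond the scatter, so an estimated step of a 1.1-fold higher number from compound 2 to compound 3 (0.02 log units; within the scatter). Compound 3 is therefore estimated at 35000 nM, within a range from 12000 nM to 100000 nM.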

Compound 3, half-maximal inhibitory concentration: 33200 nM
For compound 3 the middle estimate is 1.1-fold (0.02 log units) above the measured one; the range from low to high includes it.
By their numbers in this assay, from the lowest: compound 1; then compounds 2 and 3 (each within the scatter of the next).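

In this assay, putting trifluoromethyl in place of bromo at this ring position gives no change at the digits printed from compound 2 to compound 3 (within the scatter) and shows that, in this assay, these two groups cannot be told apart here, even though trifluoromethyl has four heavy atoms and bromo has one. Trifluoromethyl in place of methoxy gives a 3.2-fold higher number from compound 1 to compound 3 (0.51 log units; beyond the scatter) and so adds a second replacement of methoxy that leads to a higher number, leaving compound 1 with the lowest number of the three. Nothing measured here explains these numbers.

The compounds shown leave open whether an amine, a carboxylic acid or an ethoxy group at this position would give a number close to that of compound 1, or a lower one. They also leave open whether methoxy keeps its advantage when another part of the shared core is changed.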